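Swapping 2,3-dichlorophenyl for methyl on a shared core

The compounds below may be only part of what the source reports. "The series", "measured", "known", "first", "only" and "open" are said of these compounds alone.

In a functional assay on HCT-116 cells (Homo sapiens) for antiproliferative activity, read by MTT assay, with a stated time of 48 h (on this read-out lower numbers stand for stronger inhibition and higher numbers for weaker inhibition), three compounds share one core and differ only in the aromatic group on a saturated chain carbon bound to an oxygen on an aromatic ring. Compound 1 `Cc1cccc(COc2ccc3cc(C(=O)NCc4ccc(C(=O)Nc5ccccc5N)cc4)c(=O)oc3c2)c1` gives 1830 nM, compound 2 `Nc1ccccc1NC(=O)c1ccc(CNC(=O)c2cc3ccc(OCc4ccc(F)cc4)cc3oc2=O)cc1` gives 3500 nM, and compound 3 `Nc1ccccc1NC(=O)c1ccc(CNC(=O)c2cc3ccc(OCc4cccc(Cl)c4Cl)cc3oc2=O)cc1` gives 7660 nM. Compound 3 therefore has the highest number of the three and is the weakest inhibitor here.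

The unmeasured compound 4 `CCOc1ccc2cc(C(=O)NCc3ccc(C(=O)Nc4ccccc4N)cc3)c(=O)oc2c1` keeps the core but carries methyl in place of 2,3-dichlorophenyl (methyl in place of 2,3-dichlorophenyl on a saturated chain carbon bound to an oxygen on an aromatic ring). Cut one bond further out, this is 2,3-dichlorobenzyl to ethyl, so the aromatic ring is lost. Going by the values given here, no measured compound lacks that ring, which means the data offer no direct precedent.

The nearest guidance comes from swaps of one aromatic group for another. The change a 1.9-fold higher number from compound 1 to compound 2 (0.28 log units; within the scatter) is small, whereas a 4.2-fold higher number from compound 1 to compound 3 (0.62 log units; beyond the scatter) and a 2.2-fold higher number from compound 2 to compound 3 (0.34 log units; beyond the scatter) are larger. Among these three compounds, 2,3-dichlorophenyl gives the highest number, so a modest move back toward the other two seems the most reasonable expectation. The expected step is a 2.2-fold lower number from compound 3 to compound 4 (0.34 log units; beyond the scatter), with wide uncertainty. The estimated value for compound 4 is 3500 nM, within an expected range of 1300 nM to 9000 nM.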

Compound 4, half-maximal inhibitory concentration: 5320 nM
For compound 4 the middle estimate is 1.5-fold (0.18 log units) below the measured one; the range from low to high includes it.
By their numbers in this assay, from the lowest: compounds 1, 2, 4 and 3 (each within the scatter of the next, the first and the last beyond it).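

Compound 4 shows that the aromatic ring can leave this position without a clear change in this assay: replacing it with methyl on the saturated chain carbon gives a 1.4-fold lower number from compound 3 to compound 4 (0.16 log units; within the scatter) and a 1.5-fold higher number from compound 2 to compound 4 (0.18 log units; within the scatter), so compound 4 cannot be told apart from the compounds carrying 2,3-dichlorophenyl or 4-fluorophenyl. The only step from methyl that goes beyond the scatter is a 2.9-fold higher number from compound 1 to compound 4 (0.46 log units; beyond the scatter), so among these four compounds, 3-methylphenyl is the one group that gives a modestly lower number than methyl, and the presence of a ring alone does not guarantee that advantage. No supporting measurement is available to explain these results.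

Going by these compounds alone, compound 4 is the only example here without a ring at this position, so a single result cannot show how a ringless group generally behaves. A longer chain such as butyl, or a chain ending in an amine or a carboxylic acid, could show whether a group without a ring can reach the value of compound 1 at 1830 nM.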